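Series notes: dropping the phenyl from compound 2

The compounds below may be only part of what the source reports. "The series", "measured", "known", "first", "only" and "open" are said of these compounds alone.

Measured in an assay on HEK293 cells for inhibition of transient receptor potential cation channel subfamily V member 1 (Homo sapiens), read by FLIPR; a higher number here means a weaker inhibitor, a lower number a stronger inhibitor:
compound 1 `Cc1ccc(N2CCN(C(=O)Nc3ccc(C(F)(F)F)cc3)CC2)nn1` — > 10000 nM
compound 2 `O=C(Nc1ccc(C(F)(F)F)cc1)N1CCN(c2ccc(-c3ccccc3)nn2)CC1` — > 10000 nM

Compound 1 carries a methyl on an aromatic carbon of the shared core, compound 2 a phenyl in its place. Both values shown are limits of the assay, not numbers. Compound 1 in this assay reaches only the limit > 10000 nM. Compound 2 in this assay reaches only the limit > 10000 nM. The step that the two limits leave unreadable from compound 1 to compound 2 gives no size because both values stop at the limit of > 10000 nM in this assay, at which 2 of the 2 values shown sit. Where compound 2 stands is therefore known only as that limit; no number places it.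

Compound 3 `O=C(Nc1ccc(C(F)(F)F)cc1)N1CCN(c2cccnn2)CC1` differs from compound 2 in one place: hydrogen in place of phenyl on an aromatic carbon. Among the measured compounds shown here, the single measured step, methyl to phenyl, bears on the same aromatic carbon but gives no size, so nothing read from it sets a direction in this assay for compound 3. Compound 3 is expected at 20000 nM, with a range from 5000 nM to 100000 nM, and most probably reported again as a limit. The expected step is estimated as a step that the limit leaves unreadable from compound 2 to compound 3, which is no more than a guess of no readable change.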

Compound 3, half-maximal inhibitory concentration: > 10000 nM
Compound 3 gave a limit, no number; the forecaster's own chance of this, stated with the estimate: 85%; the middle value is on the limit's open side.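

In this assay compound 3 gives > 10000 nM, again a limit of the assay and not a number. No step among compound 1, compound 2 and compound 3 can be read: the limit of > 10000 nM in this assay, at which 3 of the 3 values shown sit.

The compounds shown leave open whether hydrogen, methyl and phenyl on this aromatic carbon differ at all in inhibitory concentration.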